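Pyrimidin-4-yl in place of pyridin-2-yl: working notes

The compounds below may be only part of what the source reports. "The series", "measured", "known", "first", "only" and "open" are said of these compounds alone.

In a physicochemical assay for solubility, measured as kinetic solubility, with a stated time of 1 h, at pH 7.4 (a lower number here means a less soluble compound, a higher number a more soluble compound), compound 1 (`N#CCC(=O)NC1=NN(c2ccc(Cl)c(Cl)c2)CC1`) gives 202000 nM, compound 2 (`CC(=O)N[C@@H](C)C(=O)NC1=NN(c2ccc(Cl)c(Cl)c2)CC1`) gives 58000 nM and compound 3 (`O=C(NC1=NN(c2ccc(Cl)c(Cl)c2)CC1)c1ccccn1`) gives 11000 nM, the lowest of the three. Compound 4 (`O=C(NC1=NN(c2ccc(Cl)c(Cl)c2)CC1)c1ccncn1`) has pyrimidin-4-yl in place of pyridin-2-yl on a carbonyl carbon. Two measured steps at this place bear on it: a large one, an 18-fold lower number from compound 1 to compound 3 (1.26 log units; beyond the scatter), and a modest one, a 5.3-fold lower number from compound 2 to compound 3 (0.72 log units; beyond the scatter). Neither compares one aromatic ring with another, so they guide the expectation only weakly. A modest rise in this assay is expected: a 2.3-fold higher number from compound 3 to compound 4 (0.36 log units; beyond the scatter). For compound 4 the estimate is 25000 nM, with an expected range of 8000 nM to 70000 nM.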

Compound 4, solubility: 13000 nM
Compound 4: middle estimate off by 1.9-fold (0.28 log units), on the high side; low and high end bracket the measured number.
By their numbers in this assay, from the lowest: compounds 3 and 4 (each within the scatter of the next); then compound 2; then compound 1.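

In this assay, within the data shown here, this is the first comparison of one aromatic ring with another on this carbonyl carbon, and it gives a 1.2-fold higher number from compound 3 to compound 4 (0.07 log units; within the scatter). Pyrimidin-4-yl therefore stays as far from the non-aromatic groups as pyridin-2-yl does, with a 4.5-fold lower number from compound 2 to compound 4 (0.65 log units; beyond the scatter) and a 16-fold lower number from compound 1 to compound 4 (1.19 log units; beyond the scatter). No supporting measurement bears on these steps.

Still open, on these data alone, is whether a plain phenyl ring on this carbonyl carbon would fall with pyridin-2-yl and pyrimidin-4-yl. A carboxylic acid or an amine at this place could also stand closer to cyanomethyl.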